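The source may hold more compounds than are shown below. What is called first, only, known or untested is meant among the compounds shown, and "the series" means these compounds.

Working notes on a short hydroxy-amide series.

Compound 1 `COC(=O)/C=C/NC(=O)[C@@H](O)C(C)(C)CO` and compound 2 `CC(C)(C)OC(=O)/C=C/NC(=O)[C@H](O)C(C)(C)CO` share the same core and differ in the ester group and in the configuration of the hydroxyl-bearing carbon. In an ADME assay on WI-38 cells (Homo sapiens) for inhibition, read by CellTiter-Glo, with a stated time of 48 h, tested at 100 uM (on this read-out higher numbers stand for more inhibition at the one concentration tested (going by the name of the read-out) and lower numbers for less inhibition), compound 1 gives -18%, and in this assay compound 2 gives 0%. For the measured compounds named here, compound 2 therefore stands highest of the two numbers so far, with compound 1 the nearest, its number lower by a gap beyond the scatter of repeats.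

The next step goes from compound 2 to compound 3 `COC(=O)/C=C/NC(=O)[C@H](O)C(C)(C)CO`. The change is methyl in place of tert-butyl on an oxygen next to a carbonyl group. Going by the values given here, no measured pair shows the effect of this exact change, so the step can only be expected, not read off. Given that both numbers so far sit near zero, the step from compound 2 to compound 3 is expected to be small, a number 9 percentage points lower from compound 2 to compound 3 (within the scatter), and to lie within the scatter rather than beyond it. The number for compound 3 in this assay is estimated at -9%, with a range from -30% to 12%.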

Compound 3, a percentage reported as inhibition, at one concentration (the size of the read-out at that concentration, not a potency): 4%
For compound 3 the middle estimate is 13 percentage points below the measured one, within the range that was stated.
By their numbers in this assay, from the lowest: compound 1; then compounds 2 and 3 (each within the scatter of the next).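

In this assay, methyl in place of tert-butyl on an oxygen next to a carbonyl group gives a number 4 percentage points higher from compound 2 to compound 3 (within the scatter), so this read-out at its one concentration does not tell the two groups apart at this place. Compound 3 also separates the two differences that were combined in the earlier pair of compound 1 and compound 2, and the configuration alone gives a number 22 percentage points higher from compound 1 to compound 3 (beyond the scatter), with the stereocentre at a saturated chain carbon drawn S in compound 1 and R in compound 3. That step is assigned to this stereocentre on one ground: the fact that compounds 1 and 3 differ only in the configuration as drawn

The compounds shown leave open whether the configuration step carries over to the tert-butyl ester, since the one pair that isolates it holds the methyl ester only. They also leave open whether a group other than methyl or tert-butyl on that oxygen, such as a longer chain or a benzyl group, or a carboxylic acid in place of the ester, would give a step beyond the scatter.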